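The source may report more compounds than this note shows. Statements on the series, on what has been measured and on what is new or still open speak of the compounds shown alone.

Measured compounds in a toxicity assay on HT-29 cells (Homo sapiens) for cytotoxicity; on this read-out higher numbers stand for lower toxicity in this test and lower numbers for higher toxicity in this test:
Compound 1 `CN1C(=S)[C@@H](NC(=O)c2n[nH]c(Cc3ccccc3)n2)COc2ccccc21`, reported only as a limit: > 50000 nM
Compound 2 `CC(C)Cn1nc(C(=O)N[C@H]2COc3ccccc3N(C)C2=S)nc1Cc1ccccc1`, reported only as a limit: > 100000 nM
Compound 3 `CN1C(=S)[C@@H](NC(=O)c2nc(Cc3ccccc3)n(CCC(F)(F)F)n2)COc2ccccc21`, reported only as a limit: > 100000 nM

All three compounds share one core and differ only in the group on the aromatic nitrogen. None of them gave a number in this assay; each value is a limit, which means the cells tolerated the compound up to the highest concentration tested. Compound 3 therefore stands at the limit of > 100000 nM in this assay, at which 2 of the 3 values shown sit, together with compound 2, while compound 1 sits at the limit of > 50000 nM in this assay, at which 1 of the 3 values shown sits.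

The steps between them cannot be sized: a step that the two limits leave unreadable from compound 1 to compound 2, a step that the two limits leave unreadable from compound 1 to compound 3 and a step that the two limits leave unreadable from compound 2 to compound 3 all read as changes between two limits.

Compound 4 `CN1C(=S)[C@@H](NC(=O)c2nc(Cc3ccccc3)n(CC3COC3)n2)COc2ccccc21` is not yet measured. It differs from compound 3 in one place: oxetan-3-yl in place of 2,2,2-trifluoroethyl on a saturated chain carbon bound to an aromatic nitrogen. Within the data shown here, the steps that bear on it, from compound 2 to compound 3 and from compound 1 to compound 3, show only that very different groups on this aromatic nitrogen all left the compounds without measurable toxicity. Compound 4 is thus expected to stay at the limit, a step of a number no higher from compound 3 to compound 4 (the limit leaves the size open). The estimate for compound 4 is 100000 nM, with a range from 50000 nM to 300000 nM.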

Compound 4, half-maximal cytotoxic concentration: > 100000 nM
Compound 4 was reported as a limit (the forecaster's own chance of this, stated with the estimate: 85%); the middle value sits exactly at the limit.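

In this assay, compound 4 is reported only as a limit, and compound 1, compound 2 and compound 3 are too, so none of the steps to compound 4 can be read. The compounds shown leave open whether changing the group on this aromatic nitrogen alters toxicity at all.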